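This account rests on a few compounds, and the source may have more. Where it says the series, first, only, none or still open, it means among the compounds named here.

Measured compounds:
Compound 1, `ClCc1ccc(Cn2cnc3c(Cl)ncnc32)cc1`: 1950 nM
Compound 2, `ClCc1ccccc1Cn1cnc2c(Cl)nc(Cl)nc21`: 330 nM
Compound 3, `ClCc1ccc(Cn2cnc3ncnc(Cl)c32)cc1`: "not determined" (no result reported)

The study concerns growth inhibition in a functional assay on HCT-15 cells (Homo sapiens) for cytotoxicity, read by sulforhodamine B assay, with a stated time of 48 h; a higher number here means a weaker inhibitor of growth, a lower number a stronger inhibitor of growth. Compound 1 gives 1950 nM in this assay, while compound 2 gives 330 nM; the two differ in more than one place, so no single change can be credited with the gap between them. Compound 3 has no number in this assay: its result was not reported, so it cannot be placed on the scale set by compound 1 and compound 2.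

Compound 4, `ClCc1ccc(Cn2cnc3nc(Cl)nc(Cl)c32)cc1`, differs from compound 3 by chloro in place of hydrogen on an aromatic carbon. Going by the values given here, no step between measured compounds isolates this change. Compound 2, which also bears a chloro between two ring nitrogen atoms, gives 330 nM, whereas compound 1, which lacks it, gives 1950 nM, but other differences lie between those two. The author therefore expects a modest step toward stronger growth inhibition in this assay, one that may not clearly exceed the usual scatter. Compound 4 is expected to give 800 nM, within a range from 200 nM to 3500 nM.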

Compound 4, concentration for 50% growth inhibition: 1810 nM
The estimate for compound 4 lay 2.3-fold (0.35 log units) below the measured number, and the stated range covers the measured number.
By their numbers in this assay, from the lowest: compound 2; then compounds 4 and 1 (each within the scatter of the next).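

Going by these compounds alone, compound 3 has no number in this assay, and so no step to compound 4 can be read. The compounds shown leave open what chloro in place of hydrogen between two ring nitrogen atoms does to growth inhibition. No measured evidence bears on this result.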